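This account rests on a few compounds, and the source may have more. Where it says the series, first, only, none or still open, it means among the compounds named here.

The measured compounds:

Compound 1, `Cn1nc(Cc2nnc(SCCCCCCCC(=O)Nc3ccc(Cl)cc3Cl)[nH]2)c2ccccc2c1=O`: 3500 nM
Compound 2, `Cn1nc(Cc2nnc(SCCCCCCCC(=O)Nc3ccc(Cl)cc3Cl)n2CCC(=O)O)c2ccccc2c1=O`: > 30000 nM
Compound 3, `Cn1c(Cc2nn(CCC(=O)O)c(=O)c3ccccc23)nnc1SCCCCCCCC(=O)Nc1ccc(Cl)cc1Cl`: > 30000 nM

All three were tested in an assay on 32D cells for inhibition of interleukin-15 (Mus musculus), read by resazurin assay, with stated times of 30 min and 2.5 days, in the presence of a further agent that is not named here; on this read-out lower numbers stand for stronger inhibition and higher numbers for weaker inhibition. Compound 1 gives 3500 nM there. For compound 2 the assay reports only a limit, > 30000 nM. For compound 3 the assay likewise reports only a limit, > 30000 nM. Compound 2 and compound 3 are built from the same atoms joined differently; the difference between their two cores is not broken down here.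

One change is seen directly: from compound 2 to compound 1 the change is hydrogen in place of 2-carboxyethyl on an aromatic nitrogen, and this assay moves by an at least 8.5-fold lower number from compound 2 to compound 1 (0.93 log units; beyond the scatter). That the step is only a lower bound on the true size rests on (the limit of > 30000 nM in this assay, at which 2 of the 3 values shown sit).

Compound 4, `Cn1c(Cc2n[nH]c(=O)c3ccccc23)nnc1SCCCCCCCC(=O)Nc1ccc(Cl)cc1Cl`, has not yet been measured. It arises from compound 3 by hydrogen in place of 2-carboxyethyl on an aromatic nitrogen. Among the compounds with values here, this is the same kind of change as the one from compound 2 to compound 1, but not the same change: there the hydrogen enters on an aromatic nitrogen of a five-membered aromatic ring with 3 nitrogen, here on an aromatic nitrogen of a six-membered aromatic ring with 2 nitrogen that is part of a fused or bridged system of two rings.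

Resting on the step from compound 2 to compound 1 measured in this assay, the expected step from compound 3 to compound 4 is an at least 3.7-fold lower number from compound 3 to compound 4 (0.57 log units; beyond the scatter). Compound 4 is therefore estimated at 8000 nM in this assay, expected to lie between 2000 nM and 30000 nM, with a real chance that only a limit is reported again.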

Compound 4, half-maximal inhibitory concentration: > 30000 nM
Compound 4: only a limit was reported (the forecaster's own chance of this, stated with the estimate: 35%); at least 3.7-fold (0.57 log units) between middle value and limit.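

Compound 3 and compound 4 both give only a limit in this assay, so the step between them cannot be read, and the result rests on one reported bound: the limit of > 30000 nM in this assay, at which 3 of the 4 values shown sit. The compounds shown leave open whether hydrogen in place of 2-carboxyethyl on this aromatic nitrogen changes inhibition at all, and by how much.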